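Methyl on the amine nitrogen of compound 1

The compounds below may be only part of what the source reports. "The series", "measured", "known", "first", "only" and "open" are said of these compounds alone.

Values in a functional assay on HCT-116 cells (Homo sapiens) for inhibition, read by MTT assay, with a stated time of 72 h; on this read-out higher numbers stand for weaker inhibition and lower numbers for stronger inhibition:
Compound 1 `CNCc1c(OC)cc(Oc2cccc(Nc3ccccc3)c2)cc1OC`: > 20000 nM (a limit)
Compound 2 `COc1cc(Oc2cccc(Nc3ccccc3)c2)cc(OC)c1CNCCNC(C)=O`: 18200 nM
Compound 3 `COc1cc(Oc2cccc(Nc3ccccc3)c2)cc(OC)c1CN[C@H](C)c1ccccc1`: > 20000 nM (a limit)
Compound 4 `COc1cc(Oc2cccc(Nc3ccccc3)c2)cc(OC)c1CN(C)C`: not yet measured

Compound 1 has no numerical value here, only a limit of > 20000 nM. The measured compounds cluster tightly, with the series standing at the limit of > 20000 nM in this assay, at which 2 of the 3 values shown sit.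

Compound 4 differs from compound 1 by methyl in place of hydrogen on an amine nitrogen.

The closest evidence is the other change made at that nitrogen, which gives a step that the two limits leave unreadable from compound 1 to compound 3. The remaining steps are an at least 1.0-fold lower number from compound 1 to compound 2 (0.04 log units; that floor lies within the scatter) and an at least 1.0-fold higher number from compound 2 to compound 3 (0.04 log units; that floor lies within the scatter). None of these steps is shown to go beyond the scatter, so no step beyond the scatter is expected in this assay, in either direction. Compound 4 will probably also be reported only as a limit.

The expected step is a number no higher from compound 1 to compound 4 (the limit leaves the size open).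

For compound 4 the estimated value is 20000 nM, with an expected range of 9000 nM to 40000 nM.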

Compound 4, half-maximal inhibitory concentration: 12900 nM
Beside the measured number, compound 4's estimate is 1.6-fold (0.19 log units) above it; the measured number falls inside the stated range.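

In this assay, a second methyl on this amine nitrogen turns the (methylamino)methyl group of compound 1 into the (dimethylamino)methyl group of compound 4 and gives a measured number rather than a limit, with an at least 1.5-fold lower number from compound 1 to compound 4 (0.19 log units; that floor lies within the scatter). The comparisons at the same nitrogen read an at least 1.5-fold lower number from compound 3 to compound 4 (0.19 log units; that floor lies within the scatter) and a 1.4-fold lower number from compound 2 to compound 4 (0.15 log units; within the scatter), so no substituent shown here is separated from dimethylamino by a step beyond the scatter. The limits leave the true size of the two steps from those limit compounds open: the limit of > 20000 nM in this assay, at which 2 of the 4 values shown sit.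

As far as these compounds go, whether a piperidine or morpholine ring in place of dimethylamino would give a step beyond the scatter remains open. The same holds for a carboxylic acid on a longer chain at this nitrogen.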